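Fluoro Position Swap: From Compound 3 to Compound 4

The source may report more compounds than this note shows. Statements on the series, on what has been measured and on what is new or still open speak of the compounds shown alone.

Three compounds have been measured in an ADME assay on THP-1 cells (Homo sapiens) for cytotoxicity, read by flow cytometry and propidium iodide staining, with a stated time of 72 h; a higher number here means a weaker inhibitor, a lower number a stronger inhibitor:
compound 1 `CC(=O)Nc1ccc(O)c(C(=O)/C=C/c2ccccc2)c1` gives 85500 nM;
compound 2 `COc1ccc(/C=C/C(=O)c2cc(NC(C)=O)ccc2O)cc1` gives 59200 nM;
compound 3 `CC(=O)Nc1ccc(O)c(C(=O)/C=C/c2cccc(F)c2)c1` gives 78600 nM.

Compound 3 stands within the usual scatter of both compound 1 and compound 2, so no ordering among the three can be read from these numbers. Compound 4 `CC(=O)Nc1ccc(O)c(C(=O)/C=C/c2ccc(F)cc2)c1` differs from compound 3 in one place: 4-fluorophenyl in place of 3-fluorophenyl on a double-bonded chain carbon bound to a double-bonded chain carbon. Among the compounds with values here, two measured steps bear on this: a 1.1-fold lower number from compound 1 to compound 3 (0.04 log units; within the scatter) and a 1.4-fold lower number from compound 1 to compound 2 (0.16 log units; within the scatter), both changes on the same ring and both within the scatter. Within the data shown here, no measured step moves a fluoro group from one position to another. Compound 4 is therefore expected to show no step beyond the scatter, a 1.0-fold lower number from compound 3 to compound 4 (0.00 log units; within the scatter). The estimate for compound 4 is 78000 nM, with a range from 45000 nM to 135000 nM.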

Compound 4, half-maximal inhibitory concentration: 68800 nM
For compound 4 the middle estimate is 1.1-fold (0.05 log units) above the measured one; the measured number falls inside the stated range.
By their numbers in this assay, from the lowest: compounds 2, 4, 3 and 1 (each within the scatter of the next).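

In this assay, within the data shown here, 4-fluorophenyl in place of 3-fluorophenyl gives a 1.1-fold lower number from compound 3 to compound 4 (0.06 log units; within the scatter) and so adds what the earlier compounds could not show: moving the fluoro group around this ring leaves a step within the scatter. Fluoro in place of methoxy gives a 1.2-fold higher number from compound 2 to compound 4 (0.07 log units; within the scatter) and fluoro in place of hydrogen gives a 1.2-fold lower number from compound 1 to compound 4 (0.09 log units; within the scatter) so compound 4 cannot be told apart from either. No measured evidence bears on this result.

The compounds shown leave open whether an amine or a carboxylic acid on this ring would give a step beyond the scatter.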